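Swapping a saturated ring for an aromatic ring

The source may report more compounds than this note shows. Statements on the series, on what has been measured and on what is new or still open speak of the compounds shown alone.

Compound 1 `CCCCCCOc1nc(C(F)(F)F)ccc1CNC(=O)Nc1cccc2[nH]c(=O)ccc12`: in an assay on HEK cells for antagonist activity at transient receptor potential cation channel subfamily V member 1 (Homo sapiens), read by FLIPR (on this read-out higher numbers stand for weaker inhibition and lower numbers for stronger inhibition), compound 1 gives 3.19 nM.
Compound 2 `O=C(NCc1ccc(C(F)(F)F)nc1OCC1CCCC1)Nc1cccc2[nH]c(=O)ccc12`: in this assay compound 2 gives 2.18 nM.
Compound 3 `CC1CCC(c2nc(C(F)(F)F)ccc2CNC(=O)Nc2cccc3[nH]c(=O)ccc23)CC1`: in this assay compound 3 gives 1.44 nM.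

Compound 3 holds the lowest of the three numbers. Its distance from compound 2 is within the scatter, so the two cannot be ranked, while the step of a 2.2-fold lower number from compound 1 to compound 3 (0.35 log units; beyond the scatter) is modest but real. Compound 4 `CC(C)c1cccc(-c2nc(C(F)(F)F)ccc2CNC(=O)Nc2cccc3[nH]c(=O)ccc23)c1` has not yet been measured. The change that leads to it is 3-isopropylphenyl in place of 4-methylcyclohexyl on an aromatic carbon. The shared core and the trifluoromethyl group stay in place; only the group on the aromatic carbon of the pyridine-like ring changes.

For the measured compounds named here, two measured steps touch this position: a 2.2-fold lower number from compound 1 to compound 3 (0.35 log units; beyond the scatter) and a 1.5-fold lower number from compound 2 to compound 3 (0.18 log units; within the scatter). Both replaced an oxygen-linked chain with a saturated carbon ring and gave the same or a slightly lower number. Going by the values given here, no measured step exchanges a saturated ring for an aromatic one, so the direction of the new step is not covered by the data. The safest expectation is therefore that compound 4 stays close to compound 3, with the step of a 1.4-fold higher number from compound 3 to compound 4 (0.14 log units; within the scatter) lying within the scatter. On that basis compound 4 is expected to give about 2 nM in this assay, within a range from 0.6 nM to 7 nM.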

Compound 4, half-maximal inhibitory concentration: 1.35 nM
Compound 4: the middle estimate sits 1.5-fold (0.17 log units) above what was measured; measured number inside the range.
By their numbers in this assay, from the lowest: compounds 4, 3, 2 and 1 (each within the scatter of the next, the first and the last beyond it).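

In this assay, for the compounds shown here, this is the first exchange of a saturated ring for an aromatic one on the aromatic carbon next to the ring nitrogen, and it brings no readable change (a 1.1-fold lower number from compound 3 to compound 4 (0.03 log units; within the scatter)), even with 9 heavy atoms entering in place of 7. Compound 4 also cannot be separated from the cyclopentylmethoxy compound (a 1.6-fold lower number from compound 2 to compound 4 (0.21 log units; within the scatter)), but it does stand modestly clear of the hexyloxy compound (a 2.4-fold lower number from compound 1 to compound 4 (0.37 log units; beyond the scatter)). Among these four compounds, then, the position accepts a carbon-linked aromatic ring as well as a carbon-linked saturated one, and nothing available here gives a reason for this.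

Still open, as far as these compounds go, is what the isopropyl group contributes, as a plain phenyl group or a phenyl group carrying its isopropyl elsewhere on the ring could show. From the compounds shown here alone, it is also open whether this position would keep such low numbers with a group containing an amine or a carboxylic acid.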